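A few compounds are considered here, and "the series" means these few. Any claim that something is new, unique, unknown or untested is made for them only; others in the source may bear on it.

Measured so far:
compound 1, `CC[C@@H]1/C=C(\C)C[C@H](C)C[C@H](OC)[C@H]2O[C@@](O)(C(=O)C(=O)N3CCCC[C@H]3C(=O)O[C@H](/C(C)=C/[C@@H]3CC[C@@H](Oc4ccc(O)cc4)[C@H](OC)C3)[C@H](C)[C@@H](O)CC1=O)[C@H](C)C[C@@H]2OC`: 0.8 nM
compound 2, `CC[C@@H]1/C=C(\C)C[C@H](C)C[C@H](OC)[C@H]2O[C@@](O)(C(=O)C(=O)N3CCCC[C@H]3C(=O)O[C@H](/C(C)=C/[C@@H]3CC[C@@H](O)[C@H](Oc4ccccc4)C3)[C@H](C)[C@@H](O)CC1=O)[C@H](C)C[C@@H]2OC`: 3.2 nM

In a functional assay on cells for inhibition, with Murine T-cell line (Mus musculus) as the target (a lower number here means a stronger inhibitor, a higher number a weaker inhibitor), compound 1 gives 0.8 nM, the lowest of the two numbers; compound 2 gives 3.2 nM, a gap beyond the usual scatter. The unmeasured compound 3, `CC[C@@H]1/C=C(\C)C[C@H](C)C[C@H](OC)[C@H]2O[C@@](O)(C(=O)C(=O)N3CCCC[C@H]3C(=O)O[C@H](/C(C)=C/[C@@H]3CC[C@@H](Oc4ccc(N(C)C)cc4)[C@H](OC)C3)[C@H](C)[C@@H](O)CC1=O)[C@H](C)C[C@@H]2OC`, shares the core of compound 1 and differs from it in one place: dimethylamino in place of hydroxy on an aromatic carbon. Within the data shown here, no measured pair shows this change, so its size is uncertain. Compound 3 is expected to lie close to compound 1, with a step of a 1.6-fold higher number from compound 1 to compound 3 (0.21 log units; within the scatter) not beyond the scatter. For compound 3 the estimate in this assay is 1.3 nM, ranging from 0.4 nM to 5 nM.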

Compound 3, half-maximal inhibitory concentration: 1.1 nM
The estimate for compound 3 lay 1.2-fold (0.07 log units) above the measured number; low and high end bracket the measured number.
By their numbers in this assay, from the lowest: compounds 1 and 3 (each within the scatter of the next); then compound 2.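

In this assay, dimethylamino in place of hydroxy on the aromatic carbon para to a large group gives a 1.4-fold higher number from compound 1 to compound 3 (0.14 log units; within the scatter) and so leaves the read-out unmoved. This position therefore accepts the larger dimethylamino, and the hydrogen-bond donor of hydroxy is not needed to keep the number at the level of compound 1. The data at hand offer no measured explanation for this.

On these data alone, whether a carboxylic acid or a longer chain on this aromatic carbon would fit equally well remains open. So does the effect of a primary amine there.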